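Working notes: shortening the side chain of compound 3

A few compounds are considered here, and "the series" means these few. Any claim that something is new, unique, unknown or untested is made for them only; others in the source may bear on it.

- compound 1 `CCN(CC)CCNC(=O)c1ccc(C(CC)(CC)c2ccc(OCCC(O)(CC)CC)c(C)c2)n1CC`: 230 nM
- compound 2 `CCOC(=O)C(CC(=O)OC)NC(=O)c1ccc(C(CC)(CC)c2ccc(OCCC(O)(CC)CC)c(C)c2)n1CC`: > 50000 nM (a limit)
- compound 3 `CCC(C)C(NC(=O)c1ccc(C(CC)(CC)c2ccc(OCCC(O)(CC)CC)c(C)c2)n1CC)C(=O)O`: 2620 nM
- compound 4 `CCn1c(C(=O)NC(C)C(=O)O)ccc1C(CC)(CC)c1ccc(OCCC(O)(CC)CC)c(C)c1`: not yet measured

All values come from a functional assay on HepG2 cells (Homo sapiens) for antiproliferative activity, read by MTT assay, with a stated time of 48 h; on this read-out lower numbers stand for stronger inhibition and higher numbers for weaker inhibition. Compound 3, at 2620 nM, is the higher of the two true numbers, and compound 1 is nearest at 230 nM. The entry for compound 2 is only a limit.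

The next change is methyl in place of sec-butyl on a saturated chain carbon bound to an amide-type nitrogen and a carbonyl carbon. Within the data shown here, no measured step isolates it. Two large steps involve whole groups on the same amide-type nitrogen: an 11-fold higher number from compound 1 to compound 3 (1.06 log units; beyond the scatter) and an at least 19-fold lower number from compound 2 to compound 3 (1.28 log units; beyond the scatter). Compound 4 retains the carboxy group as 1-carboxyethyl, so a value near compound 3 at 2620 nM is expected, with no step beyond the scatter. The expected step is a 1.5-fold higher number from compound 3 to compound 4 (0.18 log units; within the scatter). Compound 4 is estimated at 4000 nM, with an expected range of 900 nM to 18000 nM.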

Compound 4, half-maximal inhibitory concentration: 1740 nM
Estimate against measurement, compound 4: 2.3-fold (0.36 log units) above, within the range that was stated.
By their numbers in this assay, from the lowest: compound 1; then compounds 4 and 3 (each within the scatter of the next). At a limit, above all of these: compound 2.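

In this assay, methyl in place of sec-butyl on this saturated chain carbon gives a 1.5-fold lower number from compound 3 to compound 4 (0.18 log units; within the scatter), so this pair shows no measurable response to the change. The 1-carboxyethyl group still stands apart from the 2-(diethylamino)ethyl group: a 7.6-fold higher number from compound 1 to compound 4 (0.88 log units; beyond the scatter). Compound 2 remains separate, with an at least 28-fold lower number from compound 2 to compound 4 (1.45 log units; beyond the scatter), but its entry is only a limit: the limit of > 50000 nM in this assay, at which 1 of the 4 values shown sits.

Open, on these data alone, is whether a primary amide in place of the carboxylic acid of compound 4 would read differently. Also open, as far as these compounds go, is how a plain hydrogen or a benzyl group would read in place of methyl on this carbon.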